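A pentylamino group in place of chloro on the core

The source may report more compounds than this note shows. Statements on the series, on what has been measured and on what is new or still open speak of the compounds shown alone.

Compound 1 `C=CCOc1ccc(C(=O)Nc2ccccn2)cc1` gives 61400 nM in an in vitro assay on HEK-tsA201 cells for antagonist activity at Neuronal acetylcholine receptor; alpha3/beta4 (Homo sapiens), read by fluorescence and calcium flux; on this read-out lower numbers stand for stronger inhibition and higher numbers for weaker inhibition. Compound 2 `C=CCOc1ccc(C(=O)Nc2cccc(Cl)n2)cc1` carries chloro in place of hydrogen on an aromatic carbon; in this assay compound 2 gives > 100000 nM, which is a limit of the assay and not a number. The step recorded is an at least 1.6-fold higher number from compound 1 to compound 2 (0.21 log units; that floor lies within the scatter). Compound 3 `CCCOc1ccc(C(=O)Nc2cccc(Cl)n2)cc1` has ethyl in place of vinyl on the chain carbon bound to oxygen; in this assay compound 3 gives > 100000 nM, again only a limit. The step from compound 2 to compound 3 is a step that the two limits leave unreadable from compound 2 to compound 3. Compound 3 thus sits at the limit of > 100000 nM in this assay, at which 2 of the 3 values shown sit, without a readable number. Compound 4 `CCCCCNc1cccc(NC(=O)c2ccc(OCCC)cc2)n1` shows (pentylamino in place of chloro on an aromatic carbon). Neither measured step involves an amino group, and both are within the scatter or unreadable, so they give no direction for this change. Compound 4 is therefore expected at roughly 50000 nM, between 5000 nM and 300000 nM, an estimated step of an at least 2.0-fold lower number from compound 3 to compound 4 (0.30 log units; that floor lies within the scatter).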

Compound 4, half-maximal inhibitory concentration: > 100000 nM
Compound 4 ended at the assay's limit (the forecaster's own chance of this, stated with the estimate: 50%); middle value at least 2.0-fold (0.30 log units) away from the limit.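

No step can be read from compound 3 to compound 4, each of which gives only a limit of the assay and not a number: the limit of > 100000 nM in this assay, at which 3 of the 4 values shown sit. What pentylamino in place of chloro does in this assay stays open in the compounds shown.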